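This account rests on a few compounds, and the source may have more. Where it says the series, first, only, none or still open, it means among the compounds named here.

Three compounds have been measured in a functional assay on HT-1080 cells (Homo sapiens) for cytotoxicity, read by MTT assay, with a stated time of 72 h; on this read-out higher numbers stand for weaker inhibition and lower numbers for stronger inhibition:

Compound 1, `COc1ccccc1/C=C1\CCC/C(=C\c2cccc(OC)c2OC)C1=O`, gives 14100 nM.
Compound 2, `COc1ccc(/C=C2\CCC/C(=C\c3cccc(OC)c3OC)C2=O)c(OC)c1`, gives only a limit of the assay, > 20000 nM.
Compound 3, `COc1ccc(/C=C2\CCC/C(=C\c3ccc(OC)c(OC)c3)C2=O)cc1`, gives 7200 nM.

Compound 1 and compound 3 are built from the same atoms joined differently; the difference between the two cores is not broken down here. Their two values lie within the usual scatter of each other, so no order can be read between them.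

From compound 1 to compound 2 the change is methoxy in place of hydrogen on an aromatic carbon, and it made an at least 1.4-fold higher number from compound 1 to compound 2 (0.15 log units; that floor lies within the scatter). The size of that step is known only as a floor, because of the limit of > 20000 nM in this assay, at which 1 of the 3 values shown sits.

Compound 4, `COc1ccc(/C=C2\CCC/C(=C\c3ccc(OC)c(OC)c3)C2=O)cc1OC`, is not yet measured. It differs from compound 3 by methoxy in place of hydrogen on an aromatic carbon. Within the data shown here, this is the same kind of change as the one from compound 1 to compound 2, but not the same: there the new methoxy sits meta to a methoxy group and para to a large group, here it sits ortho to a methoxy group and meta to a large group. Given that the earlier step gave a floor of an at least 1.4-fold higher number from compound 1 to compound 2 (0.15 log units; that floor lies within the scatter), the step from compound 3 to compound 4 in this assay is expected to be a 1.7-fold higher number from compound 3 to compound 4 (0.22 log units; within the scatter), with wide uncertainty since only one such step is known. Compound 4 is therefore estimated at 12000 nM, likely between 5000 nM and 30000 nM.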

Compound 4, half-maximal inhibitory concentration: 3000 nM
For compound 4 the middle estimate is 4.0-fold (0.60 log units) above the measured one, outside the stated range (below it).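

In this assay, methoxy in place of hydrogen on an aromatic carbon gave a 2.4-fold lower number from compound 3 to compound 4 (0.38 log units; beyond the scatter), a modest step. This is the same kind of change as the earlier one, yet it did not give the same result on the two cores, so the size of its effect cannot simply be carried from one core to the other in this series: the same change on two cores in this assay, an at least 1.4-fold higher number (0.15 log units; that floor lies within the scatter) from compound 1 to compound 2 and a 2.4-fold lower number (0.38 log units; beyond the scatter) from compound 3 to compound 4, at least 3.4-fold (0.53 log units) apart, beyond the scatter of two such steps. With only two such steps, and the new methoxy sitting in a different place on each ring, the data do not show whether the place, the rest of the core or both set the result, and the earlier step is known only as a floor, since it rests on a limit of the assay: the limit of > 20000 nM in this assay, at which 1 of the 4 values shown sits.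

The compounds shown carry only methoxy groups on their aromatic rings, so it stays open whether a hydroxy group, a fluorine atom or an amine in the place of the new methoxy of compound 4 would give a lower or a higher number. As far as these compounds go, it also stays open whether a longer chain there, such as ethoxy, would keep the lower number seen for compound 4.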